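This account rests on a few compounds, and the source may have more. Where it says the series, first, only, none or still open, it means among the compounds named here.

Working notes on the series in an ADME assay on HeLa cells (Homo sapiens) for cytotoxicity, read by resazurin assay, with a stated time of 2 days; on this read-out higher numbers stand for weaker inhibition and lower numbers for stronger inhibition.

Compound 1 `Cn1c([N+](=O)[O-])cnc1/C=C/c1ccccc1` gives > 100000 nM in this assay, and this value is a limit of the assay rather than a number. Compound 2 `Cc1ccc(/C=C/c2ncc([N+](=O)[O-])n2C)cc1` gives > 100000 nM in this assay, again a limit. Compound 3 `Cn1c([N+](=O)[O-])cnc1CCc1ccccc1` likewise gives > 100000 nM in this assay, also a limit. The step from compound 1 to compound 2 is a step that the two limits leave unreadable from compound 1 to compound 2; its size cannot be read, because of the limit of > 100000 nM in this assay, at which 3 of the 3 values shown sit. The change behind that step is methyl in place of hydrogen on an aromatic carbon. The difference between the core of compound 1 and the core of compound 3 is not broken down here.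

Compound 4 `Cc1ccc(CCc2ncc([N+](=O)[O-])n2C)cc1` is not yet measured. It differs from compound 3 by methyl in place of hydrogen on an aromatic carbon, the same change as from compound 1 to compound 2, at a place described in the same words. Because the step that the two limits leave unreadable from compound 1 to compound 2 left both values at the limit, the expected step from compound 3 to compound 4 is a step that the limit leaves unreadable from compound 3 to compound 4, that is, essentially none. The expected value for compound 4 in this assay is 150000 nM, with a range from 100000 nM to 300000 nM, and most likely only a limit will again be reported.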

Compound 4, half-maximal inhibitory concentration: > 100000 nM
Compound 4 was reported as a limit; the forecaster's own chance of this, stated with the estimate: 85%; the middle value does not contradict the limit.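

No new step can be read from compound 3 to compound 4, as both values are limits of the assay: the limit of > 100000 nM in this assay, at which 4 of the 4 values shown sit.

With no value here that is a number, the compounds shown leave open whether methyl in place of hydrogen on an aromatic carbon, or the difference between the core of compound 1 and the core of compound 3, changes the read-out in this assay.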